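A few compounds are considered here, and "the series" means these few. Any claim that something is new, unique, unknown or untested is made for them only; others in the source may bear on it.

Among the compounds with values here, in a functional assay on SW-620 cells (Homo sapiens) for antiproliferative activity, read by MTT assay, with a stated time of 72 h, in the presence of a further agent that is not named here (on this read-out lower numbers stand for stronger inhibition and higher numbers for weaker inhibition), compound 3 `Nc1nc2[nH]c(CCSCCC(=O)NCc3ccncc3)cc2c(=O)[nH]1` gives 24800 nM, the highest number of the three measured so far. Compound 1 `Nc1nc2[nH]c(CCSCCC(=O)NCc3ccccn3)cc2c(=O)[nH]1` gives 11900 nM, and compound 2 `Nc1nc2[nH]c(CCSCCC(=O)N[C@@H](CCC(=O)O)C(=O)O)cc2c(=O)[nH]1` gives 387 nM. Compound 4 `Nc1nc2[nH]c(CCSCCC(=O)NCc3cccnc3)cc2c(=O)[nH]1` carries pyridin-3-yl in place of pyridin-4-yl on a saturated chain carbon bound to an amide-type nitrogen. The nearest guide is the exchange of pyridin-2-yl for pyridin-4-yl, which gave a 2.1-fold higher number from compound 1 to compound 3 (0.32 log units; beyond the scatter), a modest step. The far larger a 31-fold lower number from compound 1 to compound 2 (1.49 log units; beyond the scatter) and a 64-fold higher number from compound 2 to compound 3 (1.81 log units; beyond the scatter) involve 1,3-dicarboxypropyl, a group absent from compound 4, so they bear little on this change. The expected change is small and slightly downward, a 1.4-fold lower number from compound 3 to compound 4 (0.14 log units; within the scatter), probably not beyond the scatter. The estimate for compound 4 is 18000 nM, with an expected range of 8000 nM to 40000 nM.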

Compound 4, half-maximal inhibitory concentration: 665 nM
Compound 4: middle estimate off by 27-fold (1.43 log units), on the high side; the measured number lies below the stated range.
By their numbers in this assay, from the lowest: compounds 2 and 4 (each within the scatter of the next); then compound 1; then compound 3.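

In this assay, the choice of pyridine isomer matters far more than the first pair suggested: pyridin-3-yl in place of pyridin-4-yl gives a large step (a 37-fold lower number from compound 3 to compound 4 (1.57 log units; beyond the scatter)), and pyridin-3-yl in place of pyridin-2-yl gives another (an 18-fold lower number from compound 1 to compound 4 (1.25 log units; beyond the scatter)). The (pyridin-3-yl)methyl group also cannot be told apart from 1,3-dicarboxypropyl (a 1.7-fold higher number from compound 2 to compound 4 (0.24 log units; within the scatter)), so this amide needs no carboxylic acid to reach that level here. No measurement shown accounts for this difference between isomers.

Still open, from the compounds shown here alone, is whether a longer chain between the amide nitrogen and the pyridin-3-yl ring, or an amine on that ring, would keep this level.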